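Trading a cyanophenyl for a cyclohexyl on a shared core

A few compounds are considered here, and "the series" means these few. Any claim that something is new, unique, unknown or untested is made for them only; others in the source may bear on it.

This set of four compounds shares one core and differs only in the group attached to a carbonyl carbon. Compound 1 `COc1ccc(-c2cnc(NC(=O)c3ncc[nH]3)n2C)cc1` carries a 1H-imidazol-2-yl group there. In a toxicity assay on THP-1 cells (Homo sapiens) for inhibition (on this read-out lower numbers stand for higher toxicity in this test and higher numbers for lower toxicity in this test), compound 1 gives > 100000 nM, which is a limit of the assay rather than a number. Compound 2 `COc1ccc(-c2cnc(NC(=O)CCc3ccccc3)n2C)cc1` carries phenethyl instead. In this assay compound 2 gives > 100000 nM, again a limit. Compound 3 `COc1ccc(-c2cnc(NC(=O)c3cccc(C#N)c3)n2C)cc1` carries 3-cyanophenyl. In this assay compound 3 gives > 100000 nM, also a limit. Because all three values sit at the limit of > 100000 nM in this assay, at which 3 of the 3 values shown sit, the steps a step that the two limits leave unreadable from compound 1 to compound 2, a step that the two limits leave unreadable from compound 1 to compound 3 and a step that the two limits leave unreadable from compound 2 to compound 3 cannot be sized. Compound 3 thus stands at the assay's limit, exactly where the other measured compounds stand.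

Compound 4 `COc1ccc(-c2cnc(NC(=O)C3CCCCC3)n2C)cc1` is not yet measured; it differs from compound 3 by cyclohexyl in place of 3-cyanophenyl on a carbonyl carbon. Every measured exchange at this carbonyl carbon, across quite different groups, has left the read-out at the limit, so no step beyond the scatter is expected here either, and the expected step is a number no higher from compound 3 to compound 4 (the limit leaves the size open). Compound 4 is therefore estimated at 100000 nM in this assay, within a range from 40000 nM to 300000 nM, and most likely reported again only as a limit.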

Compound 4, half-maximal cytotoxic concentration: > 100000 nM
Compound 4: a limit, no number; the forecaster's own chance of this, stated with the estimate: 85%; the middle value lies on the limit itself.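

In this assay compound 4 gives > 100000 nM which is a limit and not a number. No step can be read between compound 4 and compound 1, compound 2 or compound 3, since all four stand at the same limit: the limit of > 100000 nM in this assay, at which 4 of the 4 values shown sit.

What the compounds shown leave open is whether any group on this carbonyl carbon would give a measurable number in this assay at all.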